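A few compounds are considered here, and "the series" means these few. Any claim that something is new, unique, unknown or untested is made for them only; others in the source may bear on it.

Within the data shown here, in a functional assay for inhibition, with Homo sapiens as the target (on this read-out lower numbers stand for an effect already at smaller amounts and higher numbers for an effect only at larger amounts of compound), compound 1 `CCC(=O)Nc1ccc(C2=NNC(=O)CC2)cc1` gives 0.64 ug/mL, the only actual number so far. Compound 2 `CN1N=C(c2ccc(N)cc2)CCC1=O` is recorded only as a limit, > 46.4 ug/mL.

Compound 3 `O=C1CCC(c2ccc(NC(=O)CCCCl)cc2)=NN1` keeps the core of compound 1 and alters its chain: chloromethyl in place of hydrogen on a saturated chain carbon, two bonds along the chain from a carbonyl carbon. This places chloromethyl in place of hydrogen on a saturated chain carbon, two bonds along the chain from a carbonyl carbon, so propanoyl becomes (3-chloropropyl)carbonyl. Among the measured compounds shown here, no measured pair shows this change, so the data give no direct size for it. With compound 1 at 0.64 ug/mL as the only anchor, no shift beyond the scatter is expected, and no firm direction. The estimated step is a 1.4-fold higher number from compound 1 to compound 3 (0.15 log units; within the scatter). For compound 3 the expected value is 0.9 ug/mL, with an estimated range of 0.2 ug/mL to 4.5 ug/mL.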

Compound 3, half-maximal effective concentration: > 46.4 ug/mL
Compound 3: no number, only a limit; the forecaster's own chance of this, stated with the estimate: 10%; middle value at least 51-fold (1.71 log units) away from the limit.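

The chain of compound 1 proves sensitive to this change: in this assay, chloromethyl in place of hydrogen on a saturated chain carbon, two bonds along the chain from a carbonyl carbon, gives an at least 72-fold higher number from compound 1 to compound 3 (1.86 log units; beyond the scatter). Compound 3 gives > 46.4 ug/mL, which is a limit and not a number. This is the only step in the series so far, and its far end lies at the limit of the assay: the limit of > 46.4 ug/mL in this assay, at which 2 of the 3 values shown sit.

The compounds shown do not separate the effect of the chlorine from that of the longer chain, so it stays open which of the two carries the loss, or whether both do. A plain butanoyl chain without chlorine, or an amine in place of the chlorine, would bear on this question.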